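Methoxy for methyl: a small change, a small expected step

This account rests on a few compounds, and the source may have more. Where it says the series, first, only, none or still open, it means among the compounds named here.

Of the compounds shown here, two sharing one core have been measured in a functional assay on HepG2 cells (Homo sapiens) for inhibition, read by CCK-8 assay, with a stated time of 48 h; a lower number here means a stronger inhibitor, a higher number a weaker inhibitor. Compound 1 `O=C1CSC(N2N=C(c3ccc(Cl)cc3)CC2c2cccc3ccccc23)=N1` carries a chloro group and gives 16500 nM. Compound 2 `Cc1ccc(C2=NN(C3=NC(=O)CS3)C(c3cccc4ccccc34)C2)cc1` carries a methyl group in its place and gives 8660 nM. Going by the values given here, that difference is a 1.9-fold lower number from compound 1 to compound 2 (0.28 log units; within the scatter), so compound 2 stands at the lowest of the two numbers, but its only neighbour, compound 1, sits within the scatter of it, and no order between the two can be claimed.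

Compound 3 `COc1ccc(C2=NN(C3=NC(=O)CS3)C(c3cccc4ccccc34)C2)cc1` has not been measured yet. Compared with compound 2 it shows (methoxy in place of methyl on an aromatic carbon). Among the compounds with values here, the only measured step that bears on this is the one at the same place, a 1.9-fold lower number from compound 1 to compound 2 (0.28 log units; within the scatter), which exchanged one small group for another without leaving the scatter. A further exchange of one small group for another at that place is therefore expected to give a step of similar size, a 1.0-fold lower number from compound 2 to compound 3 (0.01 log units; within the scatter), that is, none beyond the scatter in either direction. For compound 3 the estimate in this assay is 8500 nM, with a range from 3500 nM to 21000 nM.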

Compound 3, half-maximal inhibitory concentration: 7850 nM
The estimate for compound 3 lay 1.1-fold (0.03 log units) above the measured number; low and high end bracket the measured number.
By their numbers in this assay, from the lowest: compounds 3, 2 and 1 (each within the scatter of the next, the first and the last beyond it).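

In this assay, going from 4-methylphenyl to 4-methoxyphenyl adds an oxygen and a hydrogen-bond acceptor at this place, yet the result (a 1.1-fold lower number from compound 2 to compound 3 (0.04 log units; within the scatter)) shows no change that can be told from the scatter, so methyl and methoxy cannot be ordered here. Going by these compounds alone, the exchange of chloro for methoxy (a 2.1-fold lower number from compound 1 to compound 3 (0.32 log units; beyond the scatter)) is the first step at this place to clear the scatter, though only modestly, and compound 2 lies within the scatter of both compound 1 and compound 3, so the three small groups form a shallow series with only its two ends told apart. No measurement shown here explains how these groups act on the read-out.

On these data alone, all three groups are small and sit at the same place on the ring, so it remains open whether an amine, a carboxylic acid or a longer chain such as butoxy there would move the number well outside this narrow range. As far as these compounds go, it also remains open whether changes elsewhere on the shared core would matter more than this position does.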